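A few compounds are considered here, and "the series" means these few. Any claim that something is new, unique, unknown or untested is made for them only; others in the source may bear on it.

Measured compounds:
compound 1, `O=C(/C=C/c1ccc2c(c1)B(O)OC2)c1ccccc1`: in a toxicity assay on MCF-10A cells (Homo sapiens) for cytotoxicity, read by MTT assay, with a stated time of 48 h (a lower number here means a stronger inhibitor, a higher number a weaker inhibitor), compound 1 gives 15900 nM.
compound 2, `O=C(/C=C/c1ccc2c(c1)B(O)OC2)c1ccc(I)cc1`: compound 2 gives > 100000 nM, which is a limit of the assay and not a number.
compound 3, `O=C(/C=C/c1ccc2c(c1)B(O)OC2)c1ccc(O)cc1`: compound 3 gives 24800 nM.

Compound 3 stands highest of the two numbers, with compound 1 nearest; the step of a 1.6-fold higher number from compound 1 to compound 3 (0.19 log units; within the scatter) lies within the scatter. Compound 4, `O=C(/C=C/c1ccc2c(c1)B(O)OC2)c1ccc(C(F)(F)F)cc1`, differs from compound 3 by trifluoromethyl in place of hydroxy on an aromatic carbon. For the measured compounds named here, the steps that bear on this are an at least 6.2-fold higher number from compound 1 to compound 2 (0.79 log units; beyond the scatter) and an at least 4.0-fold lower number from compound 2 to compound 3 (0.60 log units; beyond the scatter), both beyond the scatter, with one value sitting at the limit of > 100000 nM in this assay, at which 1 of the 3 values shown sits. A higher number is therefore expected for compound 4, possibly reaching the limit again. The expected step is a 2.8-fold higher number from compound 3 to compound 4 (0.45 log units; beyond the scatter). For compound 4 the estimate in this assay is 70000 nM, ranging from 25000 nM to 200000 nM.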

Compound 4, half-maximal inhibitory concentration: 22300 nM
Beside the measured number, compound 4's estimate is 3.1-fold (0.50 log units) above it; measured number outside the range, below it.
By their numbers in this assay, from the lowest: compounds 1, 4 and 3 (each within the scatter of the next). At a limit, above all of these: compound 2.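

In this assay trifluoromethyl at this position does not separate from hydroxy or hydrogen, with a 1.1-fold lower number from compound 3 to compound 4 (0.05 log units; within the scatter) and a 1.4-fold higher number from compound 1 to compound 4 (0.15 log units; within the scatter) both giving no real change. Substitution here therefore does not by itself move the number, and iodo stands apart from trifluoromethyl, with an at least 4.4-fold lower number from compound 2 to compound 4 (0.65 log units; beyond the scatter) marking compound 2 as the exception. The value of compound 2 is a limit and not a number: the limit of > 100000 nM in this assay, at which 1 of the 4 values shown sits.

As far as these compounds go, how an amine, a carboxylic acid or a methoxy group would read at this position remains open. From the compounds shown here alone, whether bromo or chloro would follow iodo or trifluoromethyl also remains open.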